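Swapping the amide-linked pyridine ring in a kinase-type series

This account rests on a few compounds, and the source may have more. Where it says the series, first, only, none or still open, it means among the compounds named here.

Compound 1 `COc1cc(F)c(NC(=O)c2ccnc(Cl)c2)cc1Nc1nccc(-c2cn(C)c3ccccc23)n1` gives 6890 nM in a functional assay on A549 cells (Homo sapiens) for antiproliferative activity, read by MTT assay, with a stated time of 72 h; a higher number here means a weaker inhibitor, a lower number a stronger inhibitor.
Compound 2 `COc1cc(F)c(NC(=O)c2ccncc2OC)cc1Nc1nccc(-c2cn(C)c3ccccc23)n1` gives 3430 nM in this assay.
Compound 3 `COc1ccc(C(=O)Nc2cc(Nc3nccc(-c4cn(C)c5ccccc45)n3)c(OC)cc2F)nc1` gives 8200 nM in this assay.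

Compound 2 has the lowest number of the three, though the step of a 2.0-fold lower number from compound 1 to compound 2 (0.30 log units; within the scatter) stays within the scatter; only the gap to compound 3 a 2.4-fold higher number from compound 2 to compound 3 (0.38 log units; beyond the scatter) is modest but real. Compound 4 `COc1cc(F)c(NC(=O)c2ccccn2)cc1Nc1nccc(-c2cn(C)c3ccccc23)n1` is not yet measured. Relative to compound 2 the change is pyridin-2-yl in place of 3-methoxypyridin-4-yl on a carbonyl carbon. Within the data shown here, the step that bears most on this is the one to compound 3, where a ring joined the same way but still carrying a methoxy gave a modestly higher number, while the step from compound 1 a 2.0-fold lower number from compound 1 to compound 2 (0.30 log units; within the scatter) shows the methoxy ring itself mattered little. A modest rise is therefore expected, a 1.9-fold higher number from compound 2 to compound 4 (0.28 log units; within the scatter), and compound 4 is estimated at 6500 nM (range 2800 nM to 15000 nM).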

Compound 4, half-maximal inhibitory concentration: 7980 nM
Compound 4: middle estimate off by 1.2-fold (0.09 log units), on the low side, and the stated range covers the measured number.
By their numbers in this assay, from the lowest: compounds 2, 1, 4 and 3 (each within the scatter of the next, the first and the last beyond it).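

Compound 4 shows that the methoxy group on the pyridin-2-yl ring of compound 3 counts for little at this position: with hydrogen in its place, the step is a 1.0-fold lower number from compound 3 to compound 4 (0.01 log units; within the scatter). Pyridin-2-yl also cannot be told apart from 2-chloropyridin-4-yl, a 1.2-fold higher number from compound 1 to compound 4 (0.06 log units; within the scatter). 3-Methoxypyridin-4-yl now has a second modest gap, a 2.3-fold higher number from compound 2 to compound 4 (0.37 log units; beyond the scatter), though it stays within the scatter of compound 1. No measurement here explains that gap. On these data alone, whether an amine or a carboxylic acid on this pyridine ring would move the number further remains open.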